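The compounds below may be only part of what the source reports. "The series", "measured", "known", "first", "only" and "open" are said of these compounds alone.

Measured compounds, with their values in a functional assay on PC-3 cells (Homo sapiens) for inhibition, read by MTT assay, with a stated time of 72 h; on this read-out lower numbers stand for stronger inhibition and higher numbers for weaker inhibition:
compound 1 `O=C(NNC(=O)C1CC1c1ccc(OC(F)(F)F)cc1)c1ccncc1`: > 100000 nM
compound 2 `O=C(NNc1nncc2ccccc12)C1CC1c1ccc(OCC(F)(F)F)cc1`: 67000 nM
compound 3 `CC(C)=CCOc1ccc(C2CC2C(=O)NNc2nncc3ccccc23)cc1`: 81000 nM

Compound 1 stands only at a limit. In this assay compound 1 gives > 100000 nM, which is a limit of the assay and not a number (the limit of > 100000 nM in this assay, at which 1 of the 3 values shown sits). For the measured compounds named here, compound 2 gives 67000 nM and compound 3 gives 81000 nM; the single measured step, a 1.2-fold higher number from compound 2 to compound 3 (0.08 log units; within the scatter), lies within the scatter and concerns a different core and a different position.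

The next compound is compound 4 `COc1ccc(C2CC2C(=O)NNC(=O)c2ccncc2)cc1`. It differs from compound 1 by methyl in place of trifluoromethyl on an oxygen on an aromatic ring. Going by the values given here, no measured step touches this oxygen or this pair of groups, so no step bears directly on the change. Among the compounds with values here, the only comparison at hand, the flat step from compound 2 to compound 3, alters a group one bond further out on another core and cannot be carried over. With compound 1 sitting at a limit, the size of the step in this assay cannot be read from the data in either direction, and the expectation is simply that compound 4 stays weak, with a fair chance of another limit. Compound 4 is therefore estimated at 100000 nM, with a range from 30000 nM to 300000 nM. The expected step of a number no higher from compound 1 to compound 4 (the limit leaves the size open) is set against a limit and carries little weight.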

Compound 4, half-maximal inhibitory concentration: > 100000 nM
Compound 4: no number, only a limit; the forecaster's own chance of this, stated with the estimate: 60%; the middle value lies on the limit itself.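

No new step can be read between compound 1 and compound 4, as both values are limits of the assay and not numbers: the limit of > 100000 nM in this assay, at which 2 of the 4 values shown sit.

The compounds shown leave open how far trifluoromethoxy to methoxy moves the value in this assay on the core of compound 1, and how that core compares with the core of compound 2.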